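Ethylsulfanyl Replacing Methylsulfanyl on the Fluoro Analogue

The compounds below may be only part of what the source reports. "The series", "measured", "known", "first", "only" and "open" are said of these compounds alone.

Compound 1, `CSc1nnc(Cc2ccc(Cl)cc2Oc2ccccc2Cl)[nH]1`, gives 170% in a functional assay on the whole organism (strain NMRI) with Mus musculus as the target, with a stated time of 60 min, at a dose of 20 mg/kg by the intraperitoneal route; on this read-out higher numbers stand for a stronger effect at the one dose given and lower numbers for a weaker effect.
Compound 2, `CCSc1nnc(Cc2ccc(Cl)cc2Oc2ccccc2Cl)[nH]1`, gives 174%.
Compound 3, `CSc1nnc(Cc2ccc(Cl)cc2Oc2ccccc2F)[nH]1`, gives 136%.

Among these three, compound 3 stands lowest, and its gap to each of the others is beyond the scatter, as seen in the step of a number 34 percentage points lower from compound 1 to compound 3 (beyond the scatter). Compound 4, `CCSc1nnc(Cc2ccc(Cl)cc2Oc2ccccc2F)[nH]1`, is not yet measured. It differs from compound 3 by methyl in place of hydrogen on a saturated chain carbon bound to a sulfur. For the measured compounds named here, the one measured step of the same kind, a number 4 percentage points higher from compound 1 to compound 2 (within the scatter), is within the scatter. On that basis no change beyond the scatter is expected for compound 4 in this assay, so the expected step is a number 4 percentage points higher from compound 3 to compound 4 (within the scatter). Compound 4 is therefore estimated at 140%, with a range from 120% to 160%.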

Compound 4, a percentage reported as activity, at one dose (the size of the read-out at that dose, not a potency): 141%
For compound 4 the middle estimate is 1 percentage points below the measured one; the range from low to high includes it.
By their numbers in this assay, from the lowest: compounds 3 and 4 (each within the scatter of the next); then compounds 1 and 2 (each within the scatter of the next).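

On the fluoro analogue too, going from methylsulfanyl to ethylsulfanyl gives a step within the scatter in this assay (a number 5 percentage points higher from compound 3 to compound 4 (within the scatter)), so this position reads the same with chloro or fluoro on the aromatic carbon: the same change on two cores in this assay, a number 4 percentage points higher (within the scatter) from compound 1 to compound 2 and a number 5 percentage points higher (within the scatter) from compound 3 to compound 4, 1 percentage points apart, within the scatter of two such steps.
Fluoro in place of chloro also gives a large step with ethylsulfanyl present (a number 33 percentage points lower from compound 2 to compound 4 (beyond the scatter)), matching the step seen with methylsulfanyl: the same change on two cores in this assay, a number 34 percentage points lower (beyond the scatter) from compound 1 to compound 3 and a number 33 percentage points lower (beyond the scatter) from compound 2 to compound 4, 1 percentage points apart, within the scatter of two such steps.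
Across these four compounds, neither change alters the size of the other.

Still open, on these data alone, is whether a longer chain such as butyl on the sulfur would also stay within the scatter. Equally open, as far as these compounds go, is how bromo would compare with chloro and fluoro on the aromatic carbon.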